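Compound 2 to compound 4: nitro in place of chloro

The source may report more compounds than this note shows. Statements on the series, on what has been measured and on what is new or still open speak of the compounds shown alone.

In a functional assay on HepG2 cells (Homo sapiens) for cytotoxicity, read by MTT assay, with a stated time of 48 h (on this read-out higher numbers stand for weaker inhibition and lower numbers for stronger inhibition), compound 2 `O=C(CSc1nc2ccc(NC(=O)c3ccc(Cl)cc3)cc2s1)NCc1ccc(Cl)cc1` gives 17800 nM, the highest of the three numbers in hand. Compound 3 `CC(=O)Nc1ccc2nc(SCC(=O)NCc3ccccc3)sc2c1` gives 9200 nM in this assay, and the two values lie within the scatter of each other. Compound 1 `COc1ccc(CNC(=O)CSc2nc3ccc(NC(=O)c4ccc(Cl)cc4)cc3s2)cc1` gives 7400 nM in this assay. Among the compounds with values here, the one step measured so far, a 2.4-fold higher number from compound 1 to compound 2 (0.38 log units; beyond the scatter), is beyond the scatter and of modest size.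

Compound 4 `O=C(CSc1nc2ccc(NC(=O)c3ccc([N+](=O)[O-])cc3)cc2s1)NCc1ccc(Cl)cc1` is not yet measured in this assay. It differs from compound 2 by nitro in place of chloro on an aromatic carbon. Within the data shown here, no measured step bears on this change: the single step in hand concerns a chloro in place of a methoxy at a different place in the molecule, and no compound carries a nitro group anywhere. With nothing to lean on, the expectation for this assay is no step beyond the scatter in either direction, with a wide range. Compound 4 is therefore estimated at 15000 nM, expected between 6000 nM and 40000 nM. The step this estimate means, a 1.2-fold lower number from compound 2 to compound 4 (0.07 log units; within the scatter), is expected to stay within the scatter.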

Compound 4, half-maximal inhibitory concentration: > 100000 nM
Compound 4: a limit, no number; the forecaster's own chance of this, stated with the estimate: 5%; at least 6.6-fold (0.82 log units) between middle value and limit.
By their numbers in this assay, from the lowest: compounds 1, 3 and 2 (each within the scatter of the next, the first and the last beyond it). At a limit, above all of these: compound 4.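

Compound 4 carries a limit and no number: the limit of > 100000 nM in this assay, at which 1 of the 4 values shown sits.

Nitro in place of chloro, read as 4-chlorophenyl to 4-nitrophenyl on the amide carbonyl, gives an at least 5.6-fold higher number from compound 2 to compound 4 (0.74 log units; beyond the scatter) in this assay. Within the data shown here, this is the first measured change at this position, and the earlier step, a 2.4-fold higher number from compound 1 to compound 2 (0.38 log units; beyond the scatter), concerned a different place in the molecule; the group on this aromatic carbon therefore clearly affects the read-out.

The compounds shown leave open whether an amine or a nitrile at this position would also move the number upward, or whether the step belongs to the nitro group alone. They also do not tell how a nitro group would behave on the other aromatic ring, or what lies behind the step.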